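A few compounds are considered here, and "the series" means these few. Any claim that something is new, unique, unknown or untested is made for them only; others in the source may bear on it.

Measured so far in an assay on isolated protein for inhibition of Amine oxidase [flavin-containing] A (Homo sapiens), read by fluorescence, with stated times of 15 min and 20 min; on this read-out lower numbers stand for stronger inhibition and higher numbers for weaker inhibition:
Compound 1 `COc1ccc(CN2CCC(CCNC(=O)/C=C/c3cc(C(C)(C)C)c(O)c(C(C)(C)C)c3)CC2)cc1` gives 72500 nM
Compound 2 `CC(C)(C)c1cc(/C=C/C(=O)NCCC2CCN(Cc3cccc(Cl)c3)CC2)cc(C(C)(C)C)c1O` gives 65100 nM
Compound 3 `CC(C)(C)c1cc(/C=C/C(=O)NCCC2CCN(Cc3ccc(Br)cc3)CC2)cc(C(C)(C)C)c1O` gives 73200 nM

The three compounds share one core and differ only in the substituted benzyl group on the ring amine nitrogen. The number for compound 1 lies between the other two, yet neither gap carries meaning: a 1.1-fold lower number from compound 1 to compound 2 (0.05 log units; within the scatter) and a 1.0-fold higher number from compound 1 to compound 3 (0.00 log units; within the scatter) are both within the scatter, and so is a 1.1-fold higher number from compound 2 to compound 3 (0.05 log units; within the scatter). On these numbers the three compounds are indistinguishable.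

Compound 4 `CC(C)(C)c1cc(/C=C/C(=O)NCCC2CCN(Cc3ccc(C#N)cc3)CC2)cc(C(C)(C)C)c1O` has not yet been measured. It differs from compound 1 by cyano in place of methoxy on an aromatic carbon. The measured step that bears most directly on this change also replaces the methoxy on the same aromatic carbon: a 1.0-fold higher number from compound 1 to compound 3 (0.00 log units; within the scatter). The two other steps, which move between different substituted benzyl groups, are equally flat. Nothing in these numbers suggests that a cyano in this position would behave otherwise, so the expected step is a 1.0-fold lower number from compound 1 to compound 4 (0.02 log units; within the scatter), meaning no change beyond the scatter. Compound 4 is therefore estimated at 70000 nM in this assay, with a range of 35000 nM to 140000 nM.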

Compound 4, half-maximal inhibitory concentration: 78200 nM
The estimate for compound 4 lay 1.1-fold (0.05 log units) below the measured number; the range from low to high includes it.
By their numbers in this assay, from the lowest: compounds 2, 1, 3 and 4 (each within the scatter of the next).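

In this assay, the aromatic carbon that carries the methoxy in compound 1 also accepts a cyano with no readable shift: the step is a 1.1-fold higher number from compound 1 to compound 4 (0.03 log units; within the scatter), and the exchange of bromo for cyano at that carbon gives a 1.1-fold higher number from compound 3 to compound 4 (0.03 log units; within the scatter). Cyano thus joins methoxy and bromo as a third group on this carbon with indistinguishable numbers, and the comparison with the 3-chlorophenyl group, a 1.2-fold higher number from compound 2 to compound 4 (0.08 log units; within the scatter), is just as flat, so the four compounds cannot be told apart. No supporting evidence is available to explain why the numbers stay flat across these groups.

The compounds shown leave open whether an amine or a carboxylic acid on this aromatic carbon would give a number beyond the scatter, and whether the flat picture would hold with a longer chain between the ring amine nitrogen and the aromatic ring. They also leave open whether changes to the shared core would move the number, since all four compounds carry that same core.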